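An Ethylamino to Dimethylamino Swap on a Shared Core

A few compounds are considered here, and "the series" means these few. Any claim that something is new, unique, unknown or untested is made for them only; others in the source may bear on it.

In a functional assay on MCF7 cells (Homo sapiens) for antiproliferative activity, read by MTT assay, with a stated time of 48 h (on this read-out lower numbers stand for stronger inhibition and higher numbers for weaker inhibition), compound 1 `COc1ccc(C(=O)c2ccc(OC)c3c2C=CC(C)(C)O3)c(NC(=O)CO)c1`, with hydroxy on a saturated chain carbon bound to a carbonyl carbon, gives 940 nM. With methylamino at that place, compound 2 `CNCC(=O)Nc1cc(OC)ccc1C(=O)c1ccc(OC)c2c1C=CC(C)(C)O2` gives 3040 nM. With ethylamino there, compound 3 `CCNCC(=O)Nc1cc(OC)ccc1C(=O)c1ccc(OC)c2c1C=CC(C)(C)O2` gives 7230 nM, the highest number of the three and so the weakest inhibition. Compound 4 `COc1ccc(C(=O)c2ccc(OC)c3c2C=CC(C)(C)O3)c(NC(=O)CN(C)C)c1`, still unmeasured, has the same atoms as compound 3, joined differently, with dimethylamino in place of ethylamino on a saturated chain carbon bound to a carbonyl carbon.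

For the measured compounds named here, two measured steps bear on this change. The move from hydroxy to methylamino gave a 3.2-fold higher number from compound 1 to compound 2 (0.51 log units; beyond the scatter), and lengthening methylamino to ethylamino gave a 2.4-fold higher number from compound 2 to compound 3 (0.38 log units; beyond the scatter). Going by the values given here, both are modest, but no measured compound carries dimethylamino, so the comparison is only indirect. A small step towards a lower number is therefore expected, and the estimated change is a 1.4-fold lower number from compound 3 to compound 4 (0.16 log units; within the scatter). In this assay, the estimated value for compound 4 is 5000 nM, with an expected range from 2200 nM to 11500 nM.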

Compound 4, half-maximal inhibitory concentration: 6530 nM
Compound 4: the middle estimate sits 1.3-fold (0.12 log units) below what was measured; low and high end bracket the measured number.
By their numbers in this assay, from the lowest: compound 1; then compound 2; then compounds 4 and 3 (each within the scatter of the next).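

Swapping ethylamino for dimethylamino gave a 1.1-fold lower number from compound 3 to compound 4 (0.04 log units; within the scatter) in this assay, so the two groups cannot be told apart at this place, even though ethylamino carries one hydrogen-bond donor and dimethylamino none. Methyl in place of hydrogen on the amine nitrogen gave a 2.1-fold higher number from compound 2 to compound 4 (0.33 log units; beyond the scatter) and dimethylamino in place of hydroxy gave a 6.9-fold higher number from compound 1 to compound 4 (0.84 log units; beyond the scatter) in the same assay, which leaves compound 1 the strongest of the four. Nothing at hand accounts for these steps.

The compounds shown leave open whether a primary amine or a ring amine such as morpholine at this place would read like compound 2 or come closer to compound 1. They also leave open how a carboxylic acid or a longer chain carrying dimethylamino would read.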